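A few compounds are considered here, and "the series" means these few. Any claim that something is new, unique, unknown or untested is made for them only; others in the source may bear on it.

Measured so far in an ADME assay on THP-1 cells (Homo sapiens) for cytotoxicity, read by flow cytometry and propidium iodide staining, with a stated time of 72 h; on this read-out lower numbers stand for stronger inhibition and higher numbers for weaker inhibition:
Compound 1 `COc1cccc(/C=C/C(=O)c2cc(NC(C)=O)ccc2O)c1` gives 93700 nM.
Compound 2 `CC(=O)Nc1ccc(O)c(C(=O)/C=C/c2ccccc2F)c1` gives > 125000 nM.

The second entry is a limit of the assay and not a number. Compound 2 therefore has no exact position on this read-out, and its entry is the limit of > 125000 nM in this assay, at which 1 of the 2 values shown sits. Going by the values given here, compound 1 supplies the only numerical value, at 93700 nM.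

The next compound is compound 3 `CC(=O)Nc1ccc(O)c(C(=O)/C=C/c2cccc(F)c2)c1`, and the change from compound 2 is 3-fluorophenyl in place of 2-fluorophenyl on a double-bonded chain carbon bound to a double-bonded chain carbon. No measured step between two compounds is available, so the size of such a change in this assay has not been shown directly. The expectation therefore leans on compound 1 at 93700 nM. A result near the assay limit seems likely, with a real chance of another limit. The expected step of an at least 1.1-fold lower number from compound 2 to compound 3 (0.05 log units; that floor lies within the scatter) is no larger than the usual scatter. Compound 3 is estimated at 110000 nM, with an expected range from 65000 nM to 180000 nM.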

Compound 3, half-maximal inhibitory concentration: 78600 nM
For compound 3 the middle estimate is 1.4-fold (0.15 log units) above the measured one; low and high end bracket the measured number.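

In this assay, as far as these compounds go, 3-fluorophenyl in place of 2-fluorophenyl on a double-bonded chain carbon bound to a double-bonded chain carbon gives an at least 1.5-fold lower number from compound 2 to compound 3 (0.20 log units; that floor lies within the scatter), so this position now has a first reading, though its floor does not clear the scatter and the true size of the step stays unknown. Compound 2 has a limit of the assay and not a number: the limit of > 125000 nM in this assay, at which 1 of the 3 values shown sits. Fluoro in place of methoxy on an aromatic carbon gives a 1.2-fold lower number from compound 1 to compound 3 (0.08 log units; within the scatter), so this exchange shows no change that can be told from scatter on this read-out.

The only numerical step shown stays within the scatter, and whether an amine or a carboxylic acid on that aromatic carbon would give a step beyond it remains open. Also open, from the compounds shown here alone, is whether a longer chain between the carbonyl and the aromatic ring would give a step of any readable size.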